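This account rests on a few compounds, and the source may have more. Where it says the series, first, only, none or still open, it means among the compounds named here.

Of the compounds shown here, two from one series have been measured in a functional assay on UACC-62 cells (Homo sapiens) for cytotoxicity, read by sulforhodamine B assay, with a stated time of 48 h; on this read-out lower numbers stand for higher toxicity in this test and higher numbers for lower toxicity in this test. Compound 1 `ClCc1ccccc1Cn1cnc2c(Cl)nc(Cl)nc21` gives 5240 nM, the lowest of the two numbers; compound 2 `ClCc1cccc(Cn2cnc3ncnc(Cl)c32)c1` gives 38900 nM, a gap beyond the scatter. Compound 3 `Nc1nc(Cl)c2ncn(Cc3ccccc3CCl)c2n1` is not yet measured. It differs from compound 1 by amino in place of chloro on an aromatic carbon. Within the data shown here, no measured pair shows this change, so the step in this assay is an expectation only: compound 3 is expected to give a somewhat higher number, the expected step of a 1.5-fold higher number from compound 1 to compound 3 (0.18 log units; within the scatter) lying near the edge of the scatter. Compound 3 is estimated at 8000 nM, between 2500 nM and 30000 nM.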

Compound 3, concentration lethal to 50% of the cells: 8510 nM
Estimate against measurement, compound 3: 1.1-fold (0.03 log units) below, within the range that was stated.
By their numbers in this assay, from the lowest: compounds 1 and 3 (each within the scatter of the next); then compound 2.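

Amino in place of chloro on the aromatic carbon between two ring nitrogen atoms gives a 1.6-fold higher number from compound 1 to compound 3 (0.21 log units; within the scatter) in this assay. On this core, then, the chloro group at this position can give way to amino without a difference that stands out from the scatter. Nothing available gives a reason for this result.

The compounds shown leave open whether a methoxy or a dimethylamino group at this position would give a similar number. They also leave open what replacing the other chloro group would do.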